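Methyl on the Ring Nitrogen: From Compound 1 to Compound 4

The source may hold more compounds than are shown below. What is called first, only, known or untested is meant among the compounds shown, and "the series" means these compounds.

Of the compounds shown here, three with a shared core have been tested in a functional assay on the whole organism with Canis familiaris (Canis lupus familiaris) as the target; a higher number here means that more compound is needed for the effect, a lower number that less compound is needed. Compound 1 `OC(CSc1ncnc2[nH]cnc12)CN1CCN(C(c2ccc(F)cc2)c2ccc(F)cc2)CC1` gives 0.15 mg/kg, the lowest of the three numbers. Compound 2 `OC(CSc1[nH]cnc2ncnc1-2)CN1CCN(C(c2ccc(Cl)cc2Cl)c2ccc(Cl)cc2Cl)CC1` gives 0.9 mg/kg, and compound 3 `OC(CSc1[nH]cnc2ncnc1-2)CN1CCN(C(c2cccc(C(F)(F)F)c2)c2cccc(C(F)(F)F)c2)CC1` gives 1.1 mg/kg; both of these lie beyond the scatter from compound 1. No two of the measured compounds differ in only one place, so no single change can be weighed from these numbers alone.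

Compound 4 `Cn1cnc2c(SCC(O)CN3CCN(C(c4ccc(F)cc4)c4ccc(F)cc4)CC3)ncnc21` has not yet been tested. It differs from compound 1 as follows: methyl in place of hydrogen on an aromatic nitrogen. The measured compounds give no direct guide to this change, so only a small step is expected, likely toward a somewhat higher number. The expected step is a 2.0-fold higher number from compound 1 to compound 4 (0.30 log units; within the scatter). Compound 4 is estimated at 0.3 mg/kg, within 0.1 mg/kg to 1 mg/kg.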

Compound 4, dose for half-maximal effect: 1.9 mg/kg
Compound 4: middle estimate off by 6.3-fold (0.80 log units), on the low side; measured number above the stated range.
By their numbers in this assay, from the lowest: compound 1; then compounds 2, 3 and 4 (each within the scatter of the next, the first and the last beyond it).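

Methyl in place of hydrogen on an aromatic nitrogen gives a 13-fold higher number from compound 1 to compound 4 (1.10 log units; beyond the scatter) in this assay. Within the data shown here, this is the first change in the set that can be weighed on its own, and it shows that a single added carbon at this position is far from neutral in this assay. Nothing available explains why the number moves.

From the compounds shown here alone, whether an ethyl group or a longer chain on the same nitrogen would behave like methyl stays open. So does whether the step would be similar with the chlorine-bearing rings of compound 2 or the trifluoromethyl-bearing rings of compound 3.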